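A few compounds are considered here, and "the series" means these few. Any claim that something is new, unique, unknown or untested is made for them only; others in the source may bear on it.

In a functional assay on MCF7 cells (Homo sapiens) for cytotoxicity, read by MTT assay, with a stated time of 48 h (a lower number here means a stronger inhibitor, a higher number a weaker inhibitor), compound 1 `O=C1CS/C(=N/c2ccccc2)N1Cc1ccncc1` gives 65800 nM, and compound 2 `O=C1/C(=C\c2ccc(Cl)cc2)S/C(=N/c2ccccc2)N1Cc1ccncc1` gives 54900 nM. These two numbers lie within the usual scatter of each other, so the data do not rank one compound above the other. Compound 3 `COc1ccc(/C=C2/S/C(=N/c3ccccc3)N(Cc3ccncc3)C2=O)cc1OC` has not yet been measured. Its structure differs from that of compound 2 in one place: 3,4-dimethoxyphenyl in place of 4-chlorophenyl on a double-bonded chain carbon bound to a double-bonded ring carbon. In words, 3,4-dimethoxyphenyl stands in place of 4-chlorophenyl on a double-bonded chain carbon bound to a double-bonded ring carbon. Going by the values given here, no measured pair in this assay shows what a change like this does, so the expectation starts simply from compound 2 at 54900 nM. The estimated step of a 1.1-fold lower number from compound 2 to compound 3 (0.04 log units; within the scatter) is expected to stay within the scatter, with neither direction favoured. For compound 3 the expected value is 50000 nM, with an estimated range of 18000 nM to 110000 nM.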

Compound 3, half-maximal inhibitory concentration: 80700 nM
Estimate against measurement, compound 3: 1.6-fold (0.21 log units) below, within the range that was stated.
By their numbers in this assay, from the lowest: compounds 2, 1 and 3 (each within the scatter of the next).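

In this assay, going by these compounds alone, the exchange of 4-chlorophenyl for 3,4-dimethoxyphenyl on a double-bonded chain carbon bound to a double-bonded ring carbon gives a 1.5-fold higher number from compound 2 to compound 3 (0.17 log units; within the scatter) and is the first direct comparison of two groups at this place. The entering group has more heavy atoms and brings oxygen and hydrogen-bond acceptors that the leaving group lacks, yet these two aryl groups cannot be told apart in this assay. Nothing available explains why they read alike. On these data alone, both groups are six-membered carbon aromatic rings, so it remains open whether a different kind of group at this place, such as an amine or a carboxylic acid, would move the number beyond the scatter. As far as these compounds go, it also remains open whether changes elsewhere on the shared core would matter more.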